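This account rests on a few compounds, and the source may have more. Where it says the series, first, only, none or still open, it means among the compounds named here.

Measured in an assay on isolated protein for inhibition of MAP kinase-activated protein kinase 2 (Homo sapiens), read by mobility shift assay, tested at 30 uM; a lower number here means less inhibition, a higher number more inhibition at the concentration tested (going by the name of the read-out):
compound 1 `Cc1cc2nn(-c3ccccc3)c(N)c2c(=O)[nH]1`: -4%
compound 2 `Nc1c2c(=O)[nH]c(-c3ccccc3)cc2nn1-c1ccccc1`: 2%
compound 3 `COc1ccc(-c2cc3nn(-c4ccccc4)c(N)c3c(=O)[nH]2)cc1`: 7%

All three numbers sit close to zero. Compound 3 carries the highest of the three, but one of its steps, a number 5 percentage points higher from compound 2 to compound 3 (within the scatter), is within the scatter, and only the other, a number 11 percentage points higher from compound 1 to compound 3 (beyond the scatter), is beyond it; the step of a number 6 percentage points higher from compound 1 to compound 2 (within the scatter) is likewise within it. Nothing here separates the three compounds with confidence.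

Compound 4 `CN1CCN(c2ccc(-c3cc4nn(-c5ccccc5)c(N)c4c(=O)[nH]3)cc2)CC1` is the next member. It differs from compound 3 in one place: 4-methylpiperazin-1-yl in place of methoxy on an aromatic carbon. Among the measured compounds shown here, no measured step swaps methoxy for another group; the nearest comparison is the step of a number 5 percentage points higher from compound 2 to compound 3 (within the scatter), where methoxy enters in place of hydrogen on the same aromatic carbon and nothing beyond the scatter follows. The larger change in this series, a number 11 percentage points higher from compound 1 to compound 3 (beyond the scatter), concerns the whole aryl group rather than its substituent and is itself only modest.

On this basis no step beyond the scatter is expected in this assay from compound 3 to compound 4, that is a number 1 percentage points higher from compound 3 to compound 4 (within the scatter). Compound 4 is accordingly estimated at 8%, with a range from -6% to 22%.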

Compound 4, a percentage reported as inhibition, at one concentration (the size of the read-out at that concentration, not a potency): 4%
Compound 4: the middle estimate sits 4 percentage points above what was measured; the measured number falls inside the stated range.
By their numbers in this assay, from the lowest: compounds 1, 2, 4 and 3 (each within the scatter of the next, the first and the last beyond it).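

Replacing methoxy with 4-methylpiperazin-1-yl, on the aromatic carbon para to a large group, gives a number 3 percentage points lower from compound 3 to compound 4 (within the scatter) in this assay, and the same group in place of hydrogen gives a number 2 percentage points higher from compound 2 to compound 4 (within the scatter). Until now this carbon had carried only hydrogen or methoxy, so the series now shows that a substituent of 7 heavy atoms with a six-membered non-aromatic ring can stand there without a step beyond the scatter in either comparison. No measurement on hand bears on why the number stays flat across this change.

On these data alone, whether a carboxylic acid, a primary amine or a longer alkyl chain on this same carbon would give a step beyond the scatter remains open. Also open, as far as these compounds go, is whether any change to the other phenyl of the shared core would do so.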